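A few compounds are considered here, and "the series" means these few. Any claim that something is new, unique, unknown or untested is made for them only; others in the source may bear on it.

Measured compounds:
compound 1 `Cc1ccc(/C=C2\CCC/C(=C\c3ccccc3[N+](=O)[O-])C2=O)cc1`: 11000 nM
compound 2 `COc1ccc(/C=C2\CCC/C(=C\c3ccccc3[N+](=O)[O-])C2=O)cc1`: 11000 nM
compound 3 `Cc1ccc(/C=C2\CCC/C(=C\c3ccc([N+](=O)[O-])cc3)C2=O)cc1`: 6600 nM

All numbers come from a functional assay on HSC-2 cells (Homo sapiens) for cytotoxicity, with a stated time of 24 h; on this read-out lower numbers stand for higher toxicity in this test and higher numbers for lower toxicity in this test. Compounds 1 and 2 share one core; compound 3 is built on a second core, and the difference between the two cores is not broken down here. In this assay compound 3 gives 6600 nM. Compound 1 gives 11000 nM and compound 2 gives 11000 nM. All three values sit within the scatter of one another, so no order among them is claimed.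

Going by the values given here, the one single-point change measured so far runs from compound 1 to compound 2: methoxy in place of methyl on an aromatic carbon. In this assay it gave no change at the digits printed from compound 1 to compound 2 (within the scatter).

Compound 4 `COc1ccc(/C=C2\CCC/C(=C\c3ccc([N+](=O)[O-])cc3)C2=O)cc1` is not yet measured. It differs from compound 3 by methoxy in place of methyl on an aromatic carbon, the same change at the same place as from compound 1 to compound 2, now on the core of compound 3. Because no change at the digits printed from compound 1 to compound 2 (within the scatter) showed nothing beyond the scatter, the step from compound 3 to compound 4 in this assay is expected to be no change at the digits printed from compound 3 to compound 4 (within the scatter). Compound 4 is estimated at 6600 nM, with a likely range from 3300 nM to 13000 nM.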

Compound 4, half-maximal cytotoxic concentration: > 400000 nM
Compound 4 ended at the assay's limit (the forecaster's own chance of this, stated with the estimate: 5%); middle value at least 60-fold (1.78 log units) from the limit.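

In this assay, methoxy in place of methyl on an aromatic carbon gives an at least 60-fold higher number from compound 3 to compound 4 (1.78 log units; beyond the scatter), so on these two pairs the result of this change did not carry from one core to the other: the same change on two cores in this assay, no change at the digits printed (within the scatter) from compound 1 to compound 2 and an at least 60-fold higher number (1.78 log units; beyond the scatter) from compound 3 to compound 4, at least 60-fold (1.78 log units) apart, beyond the scatter of two such steps

As far as these compounds go, the value of compound 4, > 400000 nM, is a limit of the assay and not a number, so the full size of the step stays unknown.

The result rests on one pair per core; it shows that the earlier flat step was no safe guide for the core of compound 3, but not which difference between the cores is responsible, nor whether the same split holds for any other group.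

The compounds shown carry only methyl and methoxy at this place, so it remains open whether the step belongs to methoxy alone or would also appear with a hydroxyl, a chlorine or a dimethylamino group there. Also open, from the compounds shown here alone, is how a longer ether such as ethoxy would behave on each of the two cores.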